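This account rests on a few compounds, and the source may have more. Where it says the series, first, only, none or still open, it means among the compounds named here.

Measured compounds in an ADME assay for inhibition of phosphatidylcholine:ceramide cholinephosphotransferase 1 (Homo sapiens), read by mass spectrometry, with stated times of 60 min and 30 min; a lower number here means a stronger inhibitor, a higher number a weaker inhibitor:
compound 1, `CCOc1cc(CN(C)C(=O)c2c(OCCCC3CCN(C(=O)OC(C)(C)C)CC3)c3ccccc3n(C)c2=O)cc(OCC)c1`, gives 15000 nM;
compound 2, `CN(Cc1cc(C(F)(F)F)cc(C(F)(F)F)c1)C(=O)c1c(OCCCC2CCCCC2)c2ccccc2n(C)c1=O`, gives 14000 nM;
compound 3, `COc1cc(CN(C)C(=O)c2c(OCCCC3CCN(C(=O)OC4(C)CC4)CC3)c3cccnc3n(C)c2=O)cc(C(F)(F)F)c1`, gives 2400 nM.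

Compound 2 stands second highest of these three numbers. Compound 1 sits within the scatter of compound 2, so nothing separates the two, whereas compound 3 gives a lower number than compound 2 by a margin beyond the scatter. Compound 4, `CN(Cc1cc(C(F)(F)F)cc(C(F)(F)F)c1)C(=O)c1c(N2CCCCC2)c2ccccc2n(C)c1=O`, has not yet been measured. It differs from compound 2 in one place: piperidin-1-yl in place of 3-cyclohexylpropoxy on an aromatic carbon. Within the data shown here, no pair of measured compounds shows this change, so the expectation rests on compound 2 alone. The step is expected to be a 1.8-fold higher number from compound 2 to compound 4 (0.25 log units; within the scatter), toward a higher number and of modest size, possibly not beyond the scatter. Compound 4 is therefore expected to give 25000 nM, with an estimated range from 8000 nM to 80000 nM.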

Compound 4, half-maximal inhibitory concentration: > 100000 nM
Compound 4 ended at the assay's limit (the forecaster's own chance of this, stated with the estimate: 30%); middle value at least 4.0-fold (0.60 log units) away from the limit.
By their numbers in this assay, from the lowest: compound 3; then compounds 2 and 1 (each within the scatter of the next). At a limit, above all of these: compound 4.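

In this assay compound 4 gives > 100000 nM, a limit of the assay and not a number. Among these compounds, on this aromatic carbon, opposite the ring nitrogen, piperidin-1-yl in place of 3-cyclohexylpropoxy gives an at least 7.1-fold higher number from compound 2 to compound 4 (0.85 log units; beyond the scatter), the first sign that the group here matters for this inhibition. The true size of the step stays unknown, as it ends at a limit: the limit of > 100000 nM in this assay, at which 1 of the 4 values shown sits.

The compounds shown do not separate the change of linking atom from the loss of chain length. A 3-cyclohexylpropylamino group or a cyclohexyloxy group on this carbon would bear on that question.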